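Working notes: cyclobutanol to cyclohexane-carboxamide on the aromatic amine

A few compounds are considered here, and "the series" means these few. Any claim that something is new, unique, unknown or untested is made for them only; others in the source may bear on it.

Compound 1 `N#Cc1cnc(NCc2cnccc2C(F)(F)F)cc1N[C@H]1C[C@H](O)C1` is the reference point of the pair measured so far. In an ADME assay on S9 fraction from liver (Homo sapiens) for metabolic stability, with a stated time of 1 h (on this read-out higher numbers stand for a more stable compound and lower numbers for a less stable compound), compound 1 gives 96%, the highest of the two numbers in hand. Compound 2 `N#Cc1cnc(NCc2cnccc2C(F)(F)F)cc1NC[C@H]1CC[C@@H](O)CC1`, which carries (4-hydroxycyclohexyl)methyl in place of 3-hydroxycyclobutyl on a nitrogen on an aromatic ring, gives 41% in this assay; the step is a number 55 percentage points lower from compound 1 to compound 2 (beyond the scatter).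

Compound 3 `N#Cc1cnc(NCc2cnccc2C(F)(F)F)cc1N[C@H]1CC[C@@H](C(N)=O)CC1` is the next member. The change from compound 1 is 4-carbamoylcyclohexyl in place of 3-hydroxycyclobutyl on a nitrogen on an aromatic ring. Going by the values given here, the only measured step that bears on it is the one from compound 1 to compound 2, which also exchanges the four-membered ring for a six-membered one and was large and downward. Among the compounds with values here, compound 3 keeps the six-membered ring but attaches it to the nitrogen without the extra carbon and carries a carbamoyl rather than a hydroxyl, so no measured pair matches the change exactly.

A downward step is therefore expected, estimated at a number 31 percentage points lower from compound 1 to compound 3 (beyond the scatter), though with wide uncertainty. Compound 3 is expected to give about 65% in this assay, within 35% to 92%.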

Compound 3, percent of the compound remaining: 90%
For compound 3 the middle estimate is 25 percentage points below the measured one; the range from low to high includes it.
By their numbers in this assay, from the lowest: compound 2; then compounds 3 and 1 (each within the scatter of the next).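

In this assay, the six-membered ring on the nitrogen on an aromatic ring does not by itself separate a compound from the cyclobutanol, as 4-carbamoylcyclohexyl in place of 3-hydroxycyclobutyl gives a number 6 percentage points lower from compound 1 to compound 3 (within the scatter). The low number of compound 2 therefore cannot be read as a matter of ring size alone, and the second new step, a number 49 percentage points higher from compound 2 to compound 3 (beyond the scatter), shows that this position still responds strongly among substituents that carry a six-membered ring. No independent data bear on the reason for either step.

On these data alone, the step between compound 2 and compound 3 changes the methyl link and the hydroxyl-to-carbamoyl exchange together, so the share of each remains open, and 4-hydroxycyclohexyl on the same nitrogen would separate the two. Also open, as far as these compounds go, is how far the tolerance at this position extends, for example whether a carboxylic acid or an amine in place of the carbamoyl on the cyclohexyl ring would hold up in this assay.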